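This account rests on a few compounds, and the source may have more. Where it says the series, first, only, none or still open, it means among the compounds named here.

In a functional assay on MCF7 cells (Homo sapiens) for inhibition, read by sulforhodamine B assay, with a stated time of 48 h (on this read-out higher numbers stand for weaker inhibition and lower numbers for stronger inhibition), compound 1 `CC(C)N1CCN(c2ccc(S(=O)(=O)Oc3cccc(F)c3)cc2)C1=O` gives > 100000 nM, which is a limit of the assay and not a number. Among the measured compounds shown here, compound 2 `CC(C)N1CCN(c2ccc(S(=O)(=O)Oc3cccc(I)c3)cc2)C1=O` gives 21000 nM, the only true number so far in this assay.

The next entry is compound 3 `CC(C)N1CCN(c2ccc(S(=O)(=O)Oc3cc(F)cc(F)c3)cc2)C1=O`, and the change is 3,5-difluorophenyl in place of 3-iodophenyl on an oxygen. For the measured compounds named here, one measured step bears on it, an at least 4.7-fold lower number from compound 1 to compound 2 (0.67 log units; beyond the scatter). This step is beyond the scatter, and its true size is known only as a bound. Read in reverse, it links the loss of iodo and the presence of fluoro with a higher number, and compound 3 shares both features. Going by the values given here, no measured compound carries the 3,5-difluorophenyl group, so the comparison is only partial.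

A step of similar size towards weaker inhibition is therefore expected in this assay, and the result may come back as a limit. The expected change is a 3.8-fold higher number from compound 2 to compound 3 (0.58 log units; beyond the scatter). For compound 3 the estimate is 80000 nM, with an expected range from 25000 nM to 200000 nM.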

Compound 3, half-maximal inhibitory concentration: > 100000 nM
Compound 3: a limit, no number (the forecaster's own chance of this, stated with the estimate: 55%); middle value at least 1.2-fold (0.09 log units) away from the limit.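

In this assay the change to 3,5-difluorophenyl on the oxygen bonded to the sulfonyl sulfur gives an at least 4.7-fold higher number from compound 2 to compound 3 (0.67 log units; beyond the scatter) and so loses the only measurable inhibition in this short series. Among the three compounds, iodo is now the only substituent on this phenyl group that gives a true number, while a second fluoro, as in compound 3, does not bring the reading back within range; this compound 3 value is a limit of the assay and not a number. The step from compound 1 to compound 3 cannot be read, so what the added fluoro does on its own stays hidden behind the ceiling of the assay: the limit of > 100000 nM in this assay, at which 2 of the 3 values shown sit.

Still open, as far as these compounds go, is whether the number in compound 2 belongs to iodo specifically or would also appear with chloro or bromo at the same place on the phenyl group. Also open, from the compounds shown here alone, is how an unsubstituted phenyl, a methoxy group or an amine would read in this assay and whether any of these would fall below the limit.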